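The source may report more compounds than this note shows. Statements on the series, on what has been measured and on what is new or still open speak of the compounds shown alone.

Three compounds have been measured in a functional assay on MKN-45 cells (Homo sapiens) for cytotoxicity, read by MTT assay, with a stated time of 72 h; a higher number here means a weaker inhibitor, a lower number a stronger inhibitor:

Compound 1 `CN(C)CCn1cnnc1-c1cc(Oc2ccc(NC(=O)N/N=C/c3ccc(F)cc3Cl)cc2F)ccn1` gives 870 nM in this assay.
Compound 2 `CN(C)CCn1cnnc1-c1cc(Oc2ccc(NC(=O)N/N=C/c3ccc(O)c(Br)c3)cc2F)ccn1` gives 1860 nM in this assay.
Compound 3 `CN(C)CCn1cnnc1-c1cc(Oc2ccc(NC(=O)N/N=C/c3ccc(F)cc3F)cc2F)ccn1` gives 810 nM in this assay.

Compound 2 stands at the highest number of the three, that is, it is the weakest inhibitor shown. Its nearest neighbour is compound 1, reached by a 2.1-fold higher number from compound 1 to compound 2 (0.33 log units; beyond the scatter) in the reverse direction, and compound 3 lies a little further off, as a 2.3-fold lower number from compound 2 to compound 3 (0.36 log units; beyond the scatter) shows. Compound 1 and compound 3 sit within the scatter of each other, a 1.1-fold lower number from compound 1 to compound 3 (0.03 log units; within the scatter).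

Compound 4 `CN(C)CCn1cnnc1-c1cc(Oc2ccc(NC(=O)N/N=C/c3ccccc3)cc2F)ccn1` has not yet been measured. It differs from compound 2 in one place: phenyl in place of 3-bromo-4-hydroxyphenyl on a carbon with a double bond to nitrogen.

Both measured steps that leave the 3-bromo-4-hydroxyphenyl of compound 2 bear on this change. a 2.1-fold higher number from compound 1 to compound 2 (0.33 log units; beyond the scatter) and a 2.3-fold lower number from compound 2 to compound 3 (0.36 log units; beyond the scatter) show that swapping that group for a halogen-bearing phenyl lowered the number modestly in each case. Plain phenyl is a different group again, so a modest drop in the number is expected, and a result within the scatter of compound 2 is also plausible. The expected step is a 1.6-fold lower number from compound 2 to compound 4 (0.19 log units; within the scatter).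

Compound 4 is therefore estimated at 1200 nM in this assay, with a range from 500 nM to 3000 nM.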

Compound 4, half-maximal inhibitory concentration: 2730 nM
The estimate for compound 4 lay 2.3-fold (0.36 log units) below the measured number, within the range that was stated.
By their numbers in this assay, from the lowest: compounds 3 and 1 (each within the scatter of the next); then compounds 2 and 4 (each within the scatter of the next).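

The bare phenyl shows that this position, on a carbon with a double bond to nitrogen, does not treat all ring substituents alike: in this assay, taking away the bromo and hydroxy groups together leaves the number within the scatter, as a 1.5-fold higher number from compound 2 to compound 4 (0.17 log units; within the scatter) shows. Taking away the halogens of the other two rings does move the number beyond the scatter, with a 3.4-fold higher number from compound 3 to compound 4 (0.53 log units; beyond the scatter) for the 2,4-difluorophenyl and a 3.1-fold higher number from compound 1 to compound 4 (0.50 log units; beyond the scatter) for the 2-chloro-4-fluorophenyl, so among these four compounds only those two rings stand apart from plain phenyl, and the 3-bromo-4-hydroxyphenyl of compound 2 is the one substituted ring that does not. Nothing shown here gives a reason for this difference between the substituted rings.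

As far as these compounds go, each halogen-bearing ring here carries two halogens, so it stays open whether a phenyl with a single fluoro or a single chloro would match those rings or plain phenyl. From the compounds shown here alone, it is also open how a ring bearing a methoxy or an amine would compare, and whether the bromo and the hydroxy of compound 2 would each behave differently on their own.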